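This account rests on a few compounds, and the source may have more. Where it says the series, first, only, none or still open, it means among the compounds named here.

Compound 2 `N#Cc1cccc(S(=O)(=O)c2cnc3c(F)cccc3c2-c2cccc(F)c2)c1` gives the lowest of the two readings in an ADME assay on microsomes from liver (Homo sapiens) for metabolic stability, tested at 2.5 uM (on this read-out higher numbers stand for fast clearance and lower numbers for slow clearance), where compound 2 shows 0.34 mL/min; compound 1 `O=S(=O)(c1ccc(F)c(F)c1)c1cnc2c(F)cccc2c1-c1ccccc1F` in this assay gives 1.39 mL/min, a higher number by a margin beyond the usual scatter. Compound 3 `N#Cc1cccc(S(=O)(=O)c2cnc3c(F)cccc3c2-c2ccccc2F)c1` differs from compound 2 in a single place (2-fluorophenyl in place of 3-fluorophenyl on an aromatic carbon). Among the compounds with values here, no measured pair isolates this change, so only a modest shift is expected, possibly upward, within the usual scatter. Compound 3 is therefore estimated at 0.45 mL/min, with a range from 0.2 mL/min to 1 mL/min. That estimate corresponds to an expected step of a 1.3-fold higher number from compound 2 to compound 3 (0.12 log units; within the scatter).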

Compound 3, intrinsic clearance in a liver preparation (reported as CLH), per the amount of preparation that the assay uses: 0.66 mL/min
For compound 3 the middle estimate is 1.5-fold (0.17 log units) below the measured one; low and high end bracket the measured number.
By their numbers in this assay, from the lowest: compounds 2 and 3 (each within the scatter of the next); then compound 1.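

On this aromatic carbon, 2-fluorophenyl in place of 3-fluorophenyl gives a 1.9-fold higher number from compound 2 to compound 3 (0.29 log units; within the scatter) in this assay, so the two fluorophenyl isomers cannot be told apart here. With 2-fluorophenyl held constant, 3-cyanophenyl in place of 3,4-difluorophenyl on the sulfonyl sulfur gives a 2.1-fold lower number from compound 1 to compound 3 (0.32 log units; beyond the scatter), a modest step. No measurement at hand explains either step.

As far as these compounds go, what an amine or a methoxy group would give on the fluorophenyl ring remains open. So does the effect of an unsubstituted phenyl on this aromatic carbon.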